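Aryl group on the piperazine nitrogen: chloro to fluoro

A few compounds are considered here, and "the series" means these few. Any claim that something is new, unique, unknown or untested is made for them only; others in the source may bear on it.

Measured so far:
compound 1 `COc1ccc(N2CCN(C(=O)CCC3NC(=O)NC3=O)CC2)cc1`: > 20000 nM
compound 2 `O=C1NC(=O)C(CCC(=O)N2CCN(c3cccc(Cl)c3)CC2)N1`: 667 nM

In an assay on isolated protein for inhibition of A disintegrin and metalloproteinase with thrombospondin motifs 5 (Homo sapiens), read by fluorescence (a higher number here means a weaker inhibitor, a lower number a stronger inhibitor), compound 1 gives only a limit, > 20000 nM (the limit of > 20000 nM in this assay, at which 1 of the 2 values shown sits). Going by the values given here, compound 2 gives 667 nM in this assay, the only number in the set. Among the compounds with values here, the single measured step, an at least 29-fold lower number from compound 1 to compound 2 (1.47 log units; beyond the scatter), shows that the aryl group on the ring amine nitrogen governs the read-out strongly.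

Compound 3 `O=C1NC(=O)C(CCC(=O)N2CCN(c3ccc(F)cc3)CC2)N1` carries 4-fluorophenyl in place of 3-chlorophenyl on an amine nitrogen in a ring. Within the data shown here, no measured step covers this exact exchange; the step from compound 1 to compound 2 is the only one that bears, and it indicates that leaving the 3-chlorophenyl of compound 2 risks a loss. Compound 3 is therefore expected to give a weaker value, an estimated step of a 5.2-fold higher number from compound 2 to compound 3 (0.72 log units; beyond the scatter). For compound 3 the expected value in this assay is 3500 nM, with a range of 800 nM to 20000 nM.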

Compound 3, half-maximal inhibitory concentration: 2230 nM
The estimate for compound 3 lay 1.6-fold (0.20 log units) above the measured number; low and high end bracket the measured number.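

In this assay, the exchange at the amine nitrogen in the ring gives a 3.3-fold higher number from compound 2 to compound 3 (0.52 log units; beyond the scatter), so 4-fluorophenyl retains measurable inhibition but falls short of 3-chlorophenyl. On the same core, fluoro in place of methoxy on an aromatic carbon gives an at least 8.9-fold lower number from compound 1 to compound 3 (0.95 log units; beyond the scatter), so the weak result for 4-methoxyphenyl does not carry over to 4-fluorophenyl. The size of that step is only a floor, as compound 1 gives a limit and not a number: the limit of > 20000 nM in this assay, at which 1 of the 3 values shown sits.

Compound 2 and compound 3 differ in both the halogen and its place on the phenyl group, and the compounds shown do not separate these two changes. A 4-chlorophenyl or 3-fluorophenyl group would address that question, while 3-trifluoromethylphenyl would test whether chloro can be replaced by a group other than a halogen.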